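Fluorophenyl for methylphenyl on a compound at the limit

A few compounds are considered here, and "the series" means these few. Any claim that something is new, unique, unknown or untested is made for them only; others in the source may bear on it.

In a functional assay on SGC-7901 cells (Homo sapiens) for antiproliferative activity, read by MTT assay, with a stated time of 24 h (a higher number here means a weaker inhibitor, a lower number a stronger inhibitor), compound 3 (`Cc1cccc(NNC(=O)c2ccccc2NS(=O)(=O)c2cnc(O)nc2O)c1`) gives only a limit, > 20000 nM and no number. Compound 1 (`Cc1cccc(NNC(=O)c2cccc(NS(=O)(=O)c3cnc(O)nc3O)c2)c1`) also gives only a limit, > 20000 nM and no number. Compound 3 therefore shares its position with compound 1 (the limit of > 20000 nM in this assay, at which 2 of the 3 values shown sit). In this assay compound 2 (`O=C(NNc1ccccc1Cl)c1cccc(NS(=O)(=O)c2cnc(O)nc2O)c1`) does give a number, 2270 nM in this series.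

Compound 4 (`O=C(NNc1ccc(F)cc1)c1ccccc1NS(=O)(=O)c1cnc(O)nc1O`) keeps the core of compound 3 and carries 4-fluorophenyl in place of 3-methylphenyl on an amine nitrogen. Going by the values given here, the one measured step that bears on this is 2-chlorophenyl in place of 3-methylphenyl on an amine nitrogen (an at least 8.8-fold lower number from compound 1 to compound 2 (0.94 log units; beyond the scatter)). That step brought in a different group on the core of compound 1, so only a smaller move to a lower number is expected in this assay, and compound 4 may well stay at a limit. The size of change expected is an at least 1.5-fold lower number from compound 3 to compound 4 (0.18 log units; that floor lies within the scatter) on this reading. The estimate for compound 4 is 13000 nM (range 3000 nM to 35000 nM).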

Compound 4, half-maximal inhibitory concentration: > 20000 nM
Compound 4 gave a limit, no number; the forecaster's own chance of this, stated with the estimate: 50%; middle value at least 1.5-fold (0.18 log units) from the limit.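

In this assay compound 4 gives only a limit, > 20000 nM. Compound 3 also stands at a limit, so no step between the two can be read: the limit of > 20000 nM in this assay, at which 3 of the 4 values shown sit.

Going by these compounds, whether 4-fluorophenyl in place of 3-methylphenyl on an amine nitrogen changes the activity on the core of compound 3 stays open.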